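The source may hold more compounds than are shown below. What is called first, only, known or untested is meant among the compounds shown, and "the series" means these compounds.

Measured so far:
Compound 1, `CC1(C)CO[C@H]1CN([C@H](CCC(F)(F)F)C(N)=O)S(=O)(=O)c1ccc(Cl)cc1`: 262 mL/min/kg
Compound 2, `NC(=O)[C@@H](CCC(F)(F)F)N(C[C@H]1CCCCO1)S(=O)(=O)c1ccc(Cl)cc1`: > 300 mL/min/kg

Compound 1 was tested in an in vitro ADME assay on microsomes from liver (Homo sapiens) for metabolic stability, read by HPLC (a lower number here means slower removal, a higher number faster removal of the compound), where compound 1 gives 262 mL/min/kg. For compound 2 the reading in this assay is a limit of the assay, > 300 mL/min/kg, and not a number. Compound 2 thus stands at the upper edge of the numbers shown, as told by the limit of > 300 mL/min/kg in this assay, at which 1 of the 2 values shown sits. Within the data shown here, the single measured step, an at least 1.1-fold higher number from compound 1 to compound 2 (0.05 log units; that floor lies within the scatter), concerns the same place on the shared core and points toward faster removal, though its size is known only as a floor that lies within the scatter.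

Compound 3, `NC(=O)[C@@H](CCC(F)(F)F)N(C[C@H]1CCCO1)S(=O)(=O)c1ccc(Cl)cc1`, has not yet been measured in this assay. It differs from compound 2 by oxolan-2-yl in place of oxan-2-yl on a saturated chain carbon bound to a sulfonamide nitrogen. The measured step of an at least 1.1-fold higher number from compound 1 to compound 2 (0.05 log units; that floor lies within the scatter) swaps a different ring at the same place, and it does not by itself fix a direction for the change from compound 2 to compound 3; what both measured compounds do show is fast removal. The step of an at least 1.0-fold lower number from compound 2 to compound 3 (0.01 log units; that floor lies within the scatter) is therefore expected to stay within the scatter, with a fair chance that compound 3 again returns only a limit. Compound 3 is estimated at 290 mL/min/kg, between 150 mL/min/kg and 550 mL/min/kg.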

Compound 3, clearance: 231 mL/min/kg
Beside the measured number, compound 3's estimate is 1.3-fold (0.10 log units) above it; the measured number falls inside the stated range.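

Unlike the pair of compound 1 and compound 2, compound 3 gives a second plain number for a ring swap on a saturated chain carbon bound to a sulfonamide nitrogen. In this assay the swap to oxolan-2-yl from 3,3-dimethyloxetan-2-yl gives a 1.1-fold lower number from compound 1 to compound 3 (0.05 log units; within the scatter), so these two rings cannot be told apart here. Going from oxan-2-yl to oxolan-2-yl gives an at least 1.2-fold lower number from compound 2 to compound 3 (0.11 log units; that floor lies within the scatter), and the true size of this step stays unknown because compound 2 gives a limit of the assay and not a number: the limit of > 300 mL/min/kg in this assay, at which 1 of the 3 values shown sits.

All the groups shown at this place are rings containing an oxygen, so they do not tell whether an amine or an open methoxyethyl chain would move the number beyond the scatter. Nor can ring size be judged on its own from these compounds, since the only pair that differs in ring size with a firm size for the step does not exist here: one member of the oxan-2-yl to oxolan-2-yl pair is a limit, and the 3,3-dimethyloxetan-2-yl group also carries two methyl groups.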